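Swapping an aniline sulfonamide for a sulfonylurea

The source may hold more compounds than are shown below. What is called first, only, known or untested is meant among the compounds shown, and "the series" means these compounds.

Measured so far:
Compound 1, `CNS(=O)(=O)c1ccc2c(c1)C(n1ccccc1=O)=CC(C)(C)O2`: in a functional assay with Rattus norvegicus as the target (on this read-out lower numbers stand for an effect already at smaller amounts and higher numbers for an effect only at larger amounts of compound), compound 1 gives 138 nM.
Compound 2, `CC1(C)C=C(n2ccccc2=O)c2cc(S(=O)(=O)NCCO)ccc2O1`: compound 2 gives 1000 nM.
Compound 3, `CN(c1ccccc1)S(=O)(=O)c1ccc2c(c1)C(n1ccccc1=O)=CC(C)(C)O2`: compound 3 gives 9.77 nM.

Among these three, compound 3 has the lowest number, with compound 1 the nearest and compound 2 the furthest. The two measured steps show what happened at the sulfonamide: a hydroxymethyl added on the chain carbon bound to the sulfonamide nitrogen gave a 7.2-fold higher number from compound 1 to compound 2 (0.86 log units; beyond the scatter), whereas a phenyl on the sulfonamide nitrogen gave a 14-fold lower number from compound 1 to compound 3 (1.15 log units; beyond the scatter).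

Compound 4, `CC1(C)C=C(n2ccccc2=O)c2cc(S(=O)(=O)NC(=O)Nc3ccccc3)ccc2O1`, differs from compound 3 by (phenylcarbamoyl)amino in place of methyl(phenyl)amino on a sulfonyl sulfur. The phenyl ring that accompanied the large improvement is kept, but the methyl leaves and a carbonyl with two hydrogen-bond donors enters. The step from compound 1 to compound 2 is the only hint of how added donors fared here, and it went the wrong way. Compound 4 is therefore expected to fall between compound 3 and compound 1, as a 6.1-fold higher number from compound 3 to compound 4 (0.79 log units; beyond the scatter), with an estimate of 60 nM in a range from 10 nM to 400 nM.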

Compound 4, half-maximal effective concentration: 10000 nM
For compound 4 the middle estimate is 170-fold (2.22 log units) below the measured one; measured number outside the range, above it.
By their numbers in this assay, from the lowest: compound 3; then compound 1; then compound 2; then compound 4.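

At this position on the sulfonyl sulfur, keeping a phenyl ring is clearly not enough: in this assay the (phenylcarbamoyl)amino group gives a 1000-fold higher number from compound 3 to compound 4 (3.01 log units; beyond the scatter), so the low number of compound 3 does not follow from the ring alone. The same group also compares poorly with the simpler groups on the sulfonamide nitrogen, with a 10-fold higher number from compound 2 to compound 4 (1.00 log units; beyond the scatter) and a 72-fold higher number from compound 1 to compound 4 (1.86 log units; beyond the scatter). Compound 3 is now the only one of the four with no hydrogen on the sulfonamide nitrogen and has the lowest number, an observation from these compounds only.

Nothing measured here explains the rise. Going by these compounds, a benzoyl on the sulfonamide nitrogen would keep the carbonyl and the phenyl ring without the second nitrogen, so whether that nitrogen matters remains open.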